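Moving the amide chain on the shared core

The source may report more compounds than this note shows. Statements on the series, on what has been measured and on what is new or still open speak of the compounds shown alone.

Measured in a functional assay on the whole organism with Mus musculus as the target; a lower number here means that less compound is needed, a higher number that more compound is needed for the effect:
Compound 1 `CCCN(C)C(=O)Cn1c(-c2ccc(Cl)cc2)nc2cccnc21`: 11.6 mg/kg
Compound 2 `C[C@H](C(=O)N(C)C)n1c(-c2ccc(Cl)cc2)nc2cccnc21`: 43.5 mg/kg

Compound 2, at 43.5 mg/kg, has the higher of the two numbers in this assay. Compound 3 `CN(C)C(=O)CCn1c(-c2ccc(Cl)cc2)nc2cccnc21` has the same atoms joined differently: 2-(dimethylcarbamoyl)ethyl in place of 1-(dimethylcarbamoyl)ethyl on an aromatic nitrogen. Going by the values given here, only one measured step bears on this change, a 3.8-fold higher number from compound 1 to compound 2 (0.57 log units; beyond the scatter), and it swaps a different chain, so it is only a loose guide. A step of similar or smaller size towards a lower number seems likely, though the data cannot settle the direction. The expected change is a 1.8-fold lower number from compound 2 to compound 3 (0.26 log units; within the scatter). For compound 3 the estimated value is 24 mg/kg, with an expected range of 8 mg/kg to 70 mg/kg.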

Compound 3, dose for half-maximal effect: 29.4 mg/kg
Compound 3: the middle estimate sits 1.2-fold (0.09 log units) below what was measured, and the stated range covers the measured number.
By their numbers in this assay, from the lowest: compound 1; then compounds 3 and 2 (each within the scatter of the next).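

Shifting the dimethylcarbamoyl group along the ethyl chain, which also removes the defined stereocentre, stays within the scatter in this assay (a 1.5-fold lower number from compound 2 to compound 3 (0.17 log units; within the scatter)). The larger gap remains with compound 1 (a 2.5-fold higher number from compound 1 to compound 3 (0.40 log units; beyond the scatter)), so among these three compounds the placement of the amide along the ethyl chain matters less than the step away from compound 1. Nothing shown here explains either step. Still open, going by these compounds, is how a longer chain carrying the dimethylcarbamoyl group, or a carboxylic acid in place of the amide, would read in this assay.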